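Trading Methylcarbamoyl for Amino on the Side Ring

The source may hold more compounds than are shown below. What is called first, only, known or untested is meant among the compounds shown, and "the series" means these compounds.

Compound 1 `FC(F)(F)c1cc(NC[C@H]2CCCN2)c2cn[nH]c2c1`: 83%
Compound 2 `CNC(=O)c1cccc(CNc2cc(C(F)(F)F)cc3[nH]ncc23)c1`: 46%

In an assay for inhibition of Indoleamine 2,3-dioxygenase 1 (Homo sapiens), with stated times of 10 min and 60 min, tested at 100 uM (on this read-out lower numbers stand for a weaker effect and higher numbers for a stronger effect at the one concentration tested), compound 1 gives 83%, while compound 2 gives 46%, the lower of the two numbers, and the gap between them lies beyond the usual scatter. Compound 3 `Nc1cccc(CNc2cc(C(F)(F)F)cc3[nH]ncc23)c1` has not been measured. It differs from compound 2 in one place: amino in place of methylcarbamoyl on an aromatic carbon. Among the measured compounds shown here, no pair of measured compounds differs in a single place, so nothing here shows what such a swap does. The step from compound 2 to compound 3 is therefore expected to be a number 1 percentage points lower from compound 2 to compound 3 (within the scatter), that is, no change beyond the scatter. Compound 3 is estimated at 45%, between 20% and 70%.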

Compound 3, a percentage reported as inhibition, at one concentration (the size of the read-out at that concentration, not a potency): 55%
Estimate against measurement, compound 3: 10 percentage points below; the range from low to high includes it.
By their numbers in this assay, from the lowest: compounds 2 and 3 (each within the scatter of the next); then compound 1.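

In this assay, amino in place of methylcarbamoyl on the aromatic carbon gives a number 9 percentage points higher from compound 2 to compound 3 (within the scatter), so this position accepts either group without a readable change. The larger gap appears with the other exchange: 3-aminophenyl in place of pyrrolidin-2-yl gives a number 28 percentage points lower from compound 1 to compound 3 (beyond the scatter), which points to the pyrrolidin-2-yl site as the one that matters more among these compounds. No measurement shown explains either step. Going by these compounds, it remains open how a carboxylic acid or a hydroxyl would behave on this aromatic carbon, and whether a piperidine ring could stand in for pyrrolidin-2-yl.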